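From hydroxy to methoxy on compound 2

The compounds below may be only part of what the source reports. "The series", "measured", "known", "first", "only" and "open" are said of these compounds alone.

Of the compounds shown here, two have numbers so far. In a functional assay on MCF7 cells (Homo sapiens) for antiproliferative activity, read by MTT assay, with a stated time of 48 h (on this read-out higher numbers stand for weaker inhibition and lower numbers for stronger inhibition), compound 2 (`O=C(/C=C/c1ccc(O)cc1)Nc1cc2c(Nc3ccc(Cl)c(Cl)c3)ncnc2s1`) gives 60600 nM and compound 1 (`C#Cc1cccc(Nc2ncnc3cc(NC(=O)/C=C/c4ccccc4)sc23)c1`) gives 75600 nM. Compound 2 therefore stands level with compound 1, the two values lying within the usual scatter of each other, and both are high numbers, meaning weak inhibition. For the measured compounds named here, the two compounds differ in more than one place, so no measured single-change step is available as a guide.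

Compound 3 (`COc1ccc(/C=C/C(=O)Nc2cc3c(Nc4ccc(Cl)c(Cl)c4)ncnc3s2)cc1`) differs from compound 2 by methyl in place of hydrogen on an oxygen on an aromatic ring, that is, hydroxy to methoxy on the 4-hydroxyphenyl group. Going by the values given here, with no measured step to go on, no change beyond the scatter is expected in this assay. The expected 1.1-fold lower number from compound 2 to compound 3 (0.04 log units; within the scatter) stays within the scatter. Compound 3 is estimated at 55000 nM, with an expected range of 22000 nM to 100000 nM.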

Compound 3, half-maximal inhibitory concentration: 20100 nM
Compound 3: the middle estimate sits 2.7-fold (0.44 log units) above what was measured, and the stated range ends above it.
By their numbers in this assay, from the lowest: compound 3; then compounds 2 and 1 (each within the scatter of the next).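

In this assay, methyl in place of hydrogen on the oxygen of the 4-hydroxyphenyl group gives a 3.0-fold lower number from compound 2 to compound 3 (0.48 log units; beyond the scatter), a modest step, and the first sign that this position responds to a single change; the earlier pair differed in more than one place and could not show this. The hydroxy hydrogen is therefore not needed for inhibition in this pair, although the number for compound 3 remains high. For the compounds shown here, nothing measured so far bears on why the methoxy compound gives the lower number.

Still open, going by these compounds, is whether a longer chain on the same oxygen, such as ethoxy, moves the number further in the same direction. Also open, on these data alone, is how an amine or a carboxylic acid in place of the hydroxy would read in this assay.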